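Thioether-linked anilino series on prostate carcinoma cells

A few compounds are considered here, and "the series" means these few. Any claim that something is new, unique, unknown or untested is made for them only; others in the source may bear on it.

Compound 1 `O=C(CSc1nc(Nc2ccccc2)c2ccccc2n1)Nc1ccccc1F` gives 12400 nM.
Compound 2 `C=CC(=O)Nc1cccc(NC(=O)CSc2nc(Nc3cccc(C)c3)c3ccccc3n2)c1` gives 29200 nM.

Both numbers come from a functional assay on PC-3 cells (Homo sapiens) for inhibition, read by MTT assay, with a stated time of 72 h; on this read-out lower numbers stand for stronger inhibition and higher numbers for weaker inhibition. Compound 2 stands at the highest of the two numbers; its nearest neighbour is compound 1, whose number is lower by a margin beyond the scatter. The two compounds differ in more than one place, so no single step can be read between them; only the two values themselves are known.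

The next analogue is compound 3 `C=CC(=O)Nc1cccc(NC(=O)CSc2nc(Nc3ccc(Cl)cc3Cl)c3ccccc3n2)c1`, which keeps the acrylamide side of compound 2 and changes one group: 2,4-dichlorophenyl in place of 3-methylphenyl on a nitrogen on an aromatic ring. Among the measured compounds shown here, no measured pair isolates this kind of change, so there is no step to lean on. The expected step from compound 2 to compound 3 is a 1.5-fold lower number from compound 2 to compound 3 (0.16 log units; within the scatter), a move within or just beyond the scatter, with the direction open. In this assay compound 3 is therefore expected to give about 20000 nM, within the range 8000 nM to 60000 nM.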

Compound 3, half-maximal inhibitory concentration: 25700 nM
The estimate for compound 3 lay 1.3-fold (0.11 log units) below the measured number; the measured number falls inside the stated range.
By their numbers in this assay, from the lowest: compound 1; then compounds 3 and 2 (each within the scatter of the next).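

In this assay, among the compounds shown here, the only single-place pair gives a 1.1-fold lower number from compound 2 to compound 3 (0.06 log units; within the scatter) for 2,4-dichlorophenyl in place of 3-methylphenyl on a nitrogen on an aromatic ring. For the compounds shown here, this is the first direct reading at this position, and it shows that, with the acrylamide side held fixed, these two aryl groups cannot be told apart. The exchange of a single methyl-bearing ring for a ring bearing two chlorines therefore produces no shift that can be separated from repeat-measurement noise.

Nothing available bears on why the number holds across this change.

From the compounds shown here alone, how a carboxylic acid on that ring, or a longer alkyl chain in place of the ring on the same nitrogen, would read remains open. Steps from compound 1 to compound 2 and compound 3 cannot be read, so the part played by the acrylamide side also remains open.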